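This account rests on a few compounds, and the source may have more. Where it says the series, first, only, none or still open, it means among the compounds named here.

Measured compounds:
Compound 1, `COc1cc(C(=O)c2sc3ccccc3c2-c2ccc(C)cc2)cc(OC)c1OC`: in a functional assay on HL-60 cells (Homo sapiens) for antiproliferative activity, read by MTT assay, with a stated time of 72 h (on this read-out higher numbers stand for weaker inhibition and lower numbers for stronger inhibition), compound 1 gives 1400 nM.
Compound 2, `CCOc1ccc(-c2c(C(=O)c3cc(OC)c(OC)c(OC)c3)sc3ccccc23)cc1`: in this assay compound 2 gives 3500 nM.
Compound 3, `COc1cc(C(=O)c2sc3cc(C)ccc3c2Nc2ccc(C)cc2)cc(OC)c1OC`: in this assay compound 3 gives 1900 nM.

Compound 1 and compound 2 differ in a single place: ethoxy in place of methyl on an aromatic carbon. That change produced a 2.5-fold higher number from compound 1 to compound 2 (0.40 log units; beyond the scatter), so the ethoxy compound inhibits growth somewhat less strongly than the methyl compound.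

Compound 3 is built on a different core than compound 1, and the difference between the two cores is not broken down here. In this assay the gap between compound 3 and compound 1, and likewise the gap between compound 3 and compound 2, lies within the usual scatter of repeated measurements, so no order among these three can be read from the numbers.

Compound 4, `CCOc1ccc(Nc2c(C(=O)c3cc(OC)c(OC)c(OC)c3)sc3cc(C)ccc23)cc1`, has not yet been measured. It differs from compound 3 in one place only: ethoxy in place of methyl on an aromatic carbon. The place is the same as in the first pair, so this is the same change, now carried out on the core of compound 3. Among the compounds with values here, only one earlier instance is available, which makes the expectation uncertain. Because that single instance gave a 2.5-fold higher number from compound 1 to compound 2 (0.40 log units; beyond the scatter), the same change on compound 3 is expected to produce a step of a 2.2-fold higher number from compound 3 to compound 4 (0.34 log units; beyond the scatter). Compound 4 is therefore estimated at 4200 nM in this assay, with a likely range from 1700 nM to 10000 nM.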

Compound 4, half-maximal inhibitory concentration: 4000 nM
Estimate against measurement, compound 4: 1.1-fold (0.02 log units) above, within the range that was stated.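

Replacing methyl with ethoxy on the core of compound 3 gives a 2.1-fold higher number from compound 3 to compound 4 (0.32 log units; beyond the scatter) in this assay, so on this core too the ethoxy compound inhibits growth somewhat less strongly than the methyl compound. Set beside the first case, the step keeps its direction and its size does not measurably change from one core to the other: the same change on two cores in this assay, a 2.5-fold higher number (0.40 log units; beyond the scatter) from compound 1 to compound 2 and a 2.1-fold higher number (0.32 log units; beyond the scatter) from compound 3 to compound 4, 1.2-fold (0.07 log units) apart, within the scatter of two such steps. This shows that the change carried over between these two cores in this cell assay, but two pairs cannot show that it would do the same on any other core, and the numbers alone do not reveal why the ethoxy compounds are weaker.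

On these data alone, only methyl and ethoxy appear at this place, so it remains open how a shorter methoxy group, a longer propoxy chain, or an amine or a carboxylic acid there would behave. Ethoxy also differs from methyl both in its added oxygen and in its longer chain, and these pairs cannot separate the two, so it is unknown whether a plain ethyl group would give a similar step.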